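Replacing a Spiro Amine Side Chain with Fluorophenoxy

A few compounds are considered here, and "the series" means these few. Any claim that something is new, unique, unknown or untested is made for them only; others in the source may bear on it.

Three compounds share a core and were tested in an ADME assay on Vero cells (Chlorocebus sabaeus) for cytotoxicity, with a stated time of 7 days; on this read-out lower numbers stand for higher toxicity in this test and higher numbers for lower toxicity in this test. Compound 1 `COc1ccc2[nH]c(C(=O)N3CC(=O)N(Cc4ccccc4)[C@@H](CN4CCC5(CC4)CC5)C3)cc2c1` gives 17100 nM in this assay, the lowest of the two numbers that are real values. Compound 2 `O=C(c1cc2cc(C3CC3)ccc2[nH]1)N1CC(=O)N(Cc2ccccc2)[C@@H](CN2CCC(F)CC2)C1` gives 24500 nM, a gap from compound 1 that lies within the usual scatter of this assay, so the two cannot be told apart. Compound 3 `COc1ccc2[nH]c(C(=O)N3CC(=O)N(c4ccccc4)[C@@H](Cc4ccccc4)C3)cc2c1` shows only a limit, > 30000 nM, which means no number was reached.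

Compound 4 `COc1ccc2[nH]c(C(=O)N3CC(=O)N(Cc4ccccc4)[C@@H](COc4ccc(F)cc4)C3)cc2c1` differs from compound 1 in one place: a group of 8 heavy atoms (6 carbon, 1 oxygen, 1 fluorine; one six-membered aromatic ring of carbon only) in place of a group of 8 heavy atoms (7 carbon, 1 nitrogen; one three-membered non-aromatic ring of carbon only, one six-membered non-aromatic ring with 1 hetero atom), on a saturated chain carbon bound to a saturated ring carbon. Among the measured compounds shown here, no measured pair here isolates this kind of swap, so any expectation rests on the spread of the values shown. The expected step is a 1.6-fold higher number from compound 1 to compound 4 (0.21 log units; within the scatter), a modest move toward lower toxicity that may not exceed the scatter. Compound 4 is therefore estimated to give about 28000 nM in this assay, with a plausible range from 14000 nM to 60000 nM, and a real chance that only a limit is reported.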

Compound 4, half-maximal cytotoxic concentration: 33200 nM
Estimate against measurement, compound 4: 1.2-fold (0.07 log units) below, and the stated range covers the measured number.
By their numbers in this assay, from the lowest: compounds 1, 2 and 4 (each within the scatter of the next).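

In this assay, replacing the spiro amine side chain with 4-fluorophenoxy gives a 1.9-fold higher number from compound 1 to compound 4 (0.29 log units; within the scatter). Among the compounds shown here, this is the first comparison here in which only one place changes, and it shows that this saturated chain carbon can carry an aromatic ring attached through oxygen instead of a ring containing nitrogen, with no change that can be separated from ordinary assay variation. For the compounds shown here, compound 3 has a limit rather than a number, and this limit marks the only reading of its kind in the set: the limit of > 30000 nM in this assay, at which 1 of the 4 values shown sits.

Going by these compounds, whether the fluorine matters stays open, since plain phenoxy would be needed to test it, and a morpholine or a longer chain could also be compared at this position. It is also unclear whether the same swap would behave similarly on the core of compound 2.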